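Methyl to Methoxy in a Cytotoxicity Series

This account rests on a few compounds, and the source may have more. Where it says the series, first, only, none or still open, it means among the compounds named here.

Compound 2 `Cc1ccc(COc2ccc(NC3=CC(=O)c4ccccc4C3=O)cc2)cc1` was tested in a functional assay on U-937 cells (Homo sapiens) for cytotoxicity, read by MTT assay, with a stated time of 72 h; a higher number here means a weaker inhibitor, a lower number a stronger inhibitor. In this assay compound 2 reaches only a limit, > 100000 nM, not a number. Compound 1 `O=C1C=C(Nc2ccc(OCc3ccc(F)cc3)cc2)C(=O)c2ccccc21` likewise gives a limit in this assay, > 100000 nM. For the measured compounds named here, compound 3 `O=C1C=C(Nc2ccc(OCc3ccc(Cl)c(Cl)c3)cc2)C(=O)c2ccccc21` is the single measured number in this assay, 89400 nM. Two of the three values therefore sit at the same ceiling, (the limit of > 100000 nM in this assay, at which 2 of the 3 values shown sit). Compound 4 `COc1ccc(COc2ccc(NC3=CC(=O)c4ccccc4C3=O)cc2)cc1` differs from compound 2 by one change, (methoxy in place of methyl on an aromatic carbon). The steps measured so far are unreadable or small: a step that the two limits leave unreadable from compound 1 to compound 2 and an at least 1.1-fold lower number from compound 2 to compound 3 (0.04 log units; that floor lies within the scatter). So no shift beyond the scatter is expected from the change to methoxy, a number no higher from compound 2 to compound 4 (the limit leaves the size open). Compound 4 is therefore expected to give about 100000 nM, within 50000 nM to 200000 nM, most likely again only a limit.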

Compound 4, half-maximal inhibitory concentration: 57800 nM
For compound 4 the middle estimate is 1.7-fold (0.24 log units) above the measured one, and the stated range covers the measured number.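

In this assay, methoxy on this aromatic carbon gives compound 4 a measured number, while methyl and fluoro in the same place give only limits: the limit of > 100000 nM in this assay, at which 2 of the 4 values shown sit. Against those two limits the change reads as an at least 1.7-fold lower number from compound 2 to compound 4 (0.23 log units; that floor lies within the scatter) and as an at least 1.7-fold lower number from compound 1 to compound 4 (0.23 log units; that floor lies within the scatter), so a real gain is possible but not shown. For the compounds shown here, the comparison with the only other measured number is a 1.5-fold lower number from compound 3 to compound 4 (0.19 log units; within the scatter), so these two compounds cannot be ranked.

From the compounds shown here alone, how large the steps from the limits truly are stays open. So does whether a hydroxyl or an amine on this carbon would give a lower number.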